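A few compounds are considered here, and "the series" means these few. Any claim that something is new, unique, unknown or untested is made for them only; others in the source may bear on it.

Measured so far in an ADME assay on HeLa cells (Homo sapiens) for cytotoxicity, read by XTT assay; on this read-out higher numbers stand for lower toxicity in this test and lower numbers for higher toxicity in this test:
Compound 1 `CN1C(=O)c2ccccc2C(CC(=O)c2ccc(F)cc2)C1=O`: compound 1 gives a limit, > 100 uM.
Compound 2 `CCOC(=O)CCN1C(=O)c2ccccc2C(CC(=O)c2ccccc2)C1=O`: compound 2 gives a limit, > 100 uM.
Compound 3 `CS(=O)(=O)CCN1C(=O)c2ccccc2C(CC(=O)c2ccccc2)C1=O`: compound 3 gives 70.5 uM.

Among the compounds with values here, compound 3 carries the only number; the other two values sit at the limit of > 100 uM in this assay, at which 2 of the 3 values shown sit. Within the data shown here, the single step with two measured ends, an at least 1.4-fold lower number from compound 2 to compound 3 (0.15 log units; that floor lies within the scatter), stays within the scatter. Compound 4 `CSCCCN1C(=O)c2ccccc2C(CC(=O)c2ccccc2)C1=O` differs from compound 3 as (methylsulfanyl)methyl in place of methylsulfonyl on a saturated chain carbon, two bonds along the chain from an amide-type nitrogen in a ring. Among the measured compounds shown here, no measured step covers this exchange, and the one step at this position lies within the scatter, so nothing beyond the scatter is expected in this assay. Compound 4 is estimated at 100 uM, range 40 uM to 250 uM. The expected step is a 1.4-fold higher number from compound 3 to compound 4 (0.15 log units; within the scatter), with a fair chance that only a limit is reported.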

Compound 4, half-maximal toxic concentration: 63 uM
Compound 4: the middle estimate sits 1.6-fold (0.20 log units) above what was measured; the measured number falls inside the stated range.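

In this assay the exchange of methylsulfonyl for (methylsulfanyl)methyl on this chain gives a 1.1-fold lower number from compound 3 to compound 4 (0.05 log units; within the scatter) and so does not tell the two groups apart at this position. Within the data shown here, replacing ethoxycarbonyl with (methylsulfanyl)methyl at the same place gives an at least 1.5-fold lower number from compound 2 to compound 4 (0.20 log units; that floor lies within the scatter) as the only reading for that exchange. That reading is only a floor, because compound 2 gives a limit, not a number: the limit of > 100 uM in this assay, at which 2 of the 4 values shown sit.

As far as these compounds go, whether an amine or a carboxylic acid at this place would give a step beyond the scatter remains open. A longer chain carrying methylsulfonyl also remains untested in the compounds shown here.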